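This account rests on a few compounds, and the source may have more. Where it says the series, first, only, none or still open, it means among the compounds named here.

Compound 1 `CCCCCCCCCCCCCCC(NC(=O)OC(C)(C)C)C(=O)O` is the starting point. Within the data shown here, in an ADME assay on cells (Splenocyte, Mus musculus, strain BALB/c) for cytotoxicity, read by MTT assay, tested at 10 ug/mL (on this read-out lower numbers stand for a weaker effect and higher numbers for a stronger effect at the one concentration tested), compound 1 gives 5.1%, the lowest of the two numbers measured so far. Its nearest neighbour is compound 2 `CCCCCCCCCCCCCCC(CN(CC)CC)NC(=O)OC(C)(C)C`, which in this assay gives 7.8%; the step of a number 2.7 percentage points higher from compound 1 to compound 2 (within the scatter) is one that lies within the usual scatter, so the two compounds cannot be told apart on this read-out.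

Compound 3 `CCCCCCCCCCCCCCC(C(=O)O)N(CCCC)CCCC` has not yet been measured. Compared with compound 1 it carries dibutylamino in place of (tert-butoxycarbonyl)amino on a saturated chain carbon bound to a carbonyl carbon and a saturated chain carbon. Among the measured compounds shown here, the one measured step, the one from compound 1 to compound 2, changes a different group at a different place on the shared core, so it bears only loosely on this change; all it shows is that one exchange of a group on this chain left the number essentially where it was, with both compounds low. On that slim basis a small step in this assay is expected for compound 3, of a size a number 3.9 percentage points higher from compound 1 to compound 3 (within the scatter), most likely staying within the scatter. The value of compound 3 is therefore estimated at 9%, in a range from 0% to 28%.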

Compound 3, a percentage reported as activity, at one concentration (the size of the read-out at that concentration, not a potency): 12.5%
Compound 3: the middle estimate sits 3.5 percentage points below what was measured; low and high end bracket the measured number.
By their numbers in this assay, from the lowest: compounds 1, 2 and 3 (each within the scatter of the next).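

In this assay, putting dibutylamino in place of (tert-butoxycarbonyl)amino on a saturated chain carbon bound to a carbonyl carbon and a saturated chain carbon gives a number 7.4 percentage points higher from compound 1 to compound 3 (within the scatter). Among these compounds, this is the first look at this place on the shared core, and the exchange is a large one in kind: the group that leaves holds a carbonyl and a hydrogen-bond donor, while the group that enters has no donor and carries two butyl chains, yet the two compounds cannot be told apart on this read-out. Nothing measured on these compounds points to why the number stays in this range, so no cause can be given for the result.

The compounds shown leave open what a primary amine, or a smaller dimethylamino group, would give at this same place with the carboxylic acid kept. They also leave open whether a shorter saturated chain on the shared core would give a number that differs from these, or whether dibutylamino combined with (diethylamino)methyl in place of carboxy would do so.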